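Swapping Acetamido for Methoxy on Compound 1

The source may hold more compounds than are shown below. What is called first, only, known or untested is meant among the compounds shown, and "the series" means these compounds.

Of the compounds shown here, three have so far been measured in an assay on HEK293 cells for inhibition of protein deacetylase HDAC6 (Homo sapiens); on this read-out lower numbers stand for stronger inhibition and higher numbers for weaker inhibition. Compound 1 `CCOC(=S)SCC(=O)c1ccc(NC(C)=O)cc1` gives 90 nM in this assay. Compound 2 `CCSC(=S)SCC(=O)c1ccc(C(=O)NCc2ccccc2)s1` gives 44 nM, and compound 3 `CCSC(=S)SCC(=O)c1cccc(NC(C)=O)c1` gives 329 nM. Among these three numbers, compound 1 stands second highest: compound 2 shows a lower number, a gap beyond the usual scatter, while compound 3 shows a higher number, also beyond the scatter. Going by the values given here, no two of these measured compounds differ from each other in a single place, so no isolated step between them is available to guide the next case.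

Compound 4 `CCOC(=S)SCC(=O)c1ccc(OC)cc1` has not yet been measured in this assay. It differs from compound 1 in one place: methoxy in place of acetamido on an aromatic carbon. Among the compounds with values here, with no measured step that isolates this change, the expectation rests on compound 1 alone, whose value of 90 nM serves as the anchor. Compound 4 is expected to give about 150 nM in this assay, with a range from 50 nM to 450 nM. The expected step of a 1.7-fold higher number from compound 1 to compound 4 (0.22 log units; within the scatter) is therefore a modest move toward a higher number, small enough that it may not clear the scatter of repeated measurements.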

Compound 4, half-maximal inhibitory concentration: 448 nM
Compound 4: middle estimate off by 3.0-fold (0.48 log units), on the low side; low and high end bracket the measured number.
By their numbers in this assay, from the lowest: compound 2; then compound 1; then compounds 3 and 4 (each within the scatter of the next).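

Methoxy in place of acetamido on an aromatic carbon, para to a group of 9 heavy atoms, brings a 5.0-fold higher number from compound 1 to compound 4 (0.70 log units; beyond the scatter) in this assay, and this is the first change among these compounds that can be read in isolation. It shows that this position is not indifferent to what it carries: the higher number comes with the swap from acetamido, with 4 heavy atoms and 1 hydrogen-bond donor, to methoxy, with 2 heavy atoms and 0 hydrogen-bond donors, and this single step cannot separate the heavy-atom count from the donor count. No measurement shown here bears on why the number rises, so the step stands without an explanation.

On these data alone, how an amine, a hydroxyl or a longer acyl chain such as propanamido would compare with acetamido and methoxy on this same aromatic carbon remains open. Also open, as far as these compounds go, is whether replacing acetamido with methoxy on the core of compound 3 would produce a step of similar size.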